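Replacing a Chloroethenyl Group by Hydroxy: Cytotoxicity Outlook

The source may hold more compounds than are shown below. What is called first, only, known or untested is meant among the compounds shown, and "the series" means these compounds.

Compound 1, `CC#Cc1cn([C@H]2C[C@H](O)[C@@H](CO)O2)c(=O)[nH]c1=O`, gives > 200000 nM in an ADME assay on L1210/0 cells (Mus musculus) for cytotoxicity, with a stated time of 48 h (a higher number here means a weaker inhibitor, a lower number a stronger inhibitor), which is a limit of that assay.
Compound 2, `O=c1[nH]c(=O)n([C@H]2C[C@H](O)[C@@H](CO)O2)cc1/C=C/Cl`, gives > 200000 nM in this assay, again a limit.

Among the measured compounds shown here, the single measured step, a step that the two limits leave unreadable from compound 1 to compound 2, cannot be read, as the limit of > 200000 nM in this assay, at which 2 of the 2 values shown sit, shows. Compound 2 therefore stands at the edge of what this assay can report, and no number separates it from compound 1.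

Compound 3, `O=c1[nH]c(=O)n([C@H]2C[C@H](O)[C@@H](CO)O2)cc1O`, is not yet measured. It differs from compound 2 by hydroxy in place of 2-chloroethenyl on an aromatic carbon. For the measured compounds named here, no measured step involves a hydroxy group, so the expectation rests only on where compound 2 sits. Since compound 2 sits at a limit, the expected step that the limit leaves unreadable from compound 2 to compound 3 is one without a readable direction beyond the scatter. Compound 3 is estimated at 300000 nM, with a range from 50000 nM to 2000000 nM, and most likely this assay will again report only a limit.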

Compound 3, half-maximal inhibitory concentration: > 200000 nM
Compound 3 gave a limit, no number; the forecaster's own chance of this, stated with the estimate: 85%; the middle value lies beyond the limit too.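

Among the compounds shown here, no step between compound 1, compound 2 and compound 3 can be read in this assay, because all three values are one and the same limit: the limit of > 200000 nM in this assay, at which 3 of the 3 values shown sit. The compounds shown leave open whether prop-1-yn-1-yl, 2-chloroethenyl and hydroxy differ at all in cytotoxicity, and which group on this aromatic carbon, if any, would give a readable number.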